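Chloro on the Fused Ring: Expected Effect in Cell Assay

The source may hold more compounds than are shown below. What is called first, only, known or untested is meant among the compounds shown, and "the series" means these compounds.

Compound 1 `N#Cc1nc2c(-c3nc4ccccc4[nH]3)c(N)n(CCN3CCCC3)c2nc1C#N`: in a functional assay on HeLa cells (Homo sapiens) for antiproliferative activity, read by MTT assay, with a stated time of 48 h (on this read-out higher numbers stand for weaker inhibition and lower numbers for stronger inhibition), compound 1 gives only the assay limit > 50000 nM.
Compound 2 `CN(C)CCCn1c(N)c(-c2nc3ccccc3[nH]2)c2nc(C#N)c(C#N)nc21`: in this assay compound 2 gives 25900 nM.

Compound 2 holds the only number shown; the other value is a limit. The step of an at least 1.9-fold lower number from compound 1 to compound 2 (0.28 log units; that floor lies within the scatter) is the only one measured. It rests on the limit of compound 1, (the limit of > 50000 nM in this assay, at which 1 of the 2 values shown sits). Compound 3 `CN(C)CCCn1c(N)c(-c2nc3cc(Cl)ccc3[nH]2)c2nc(C#N)c(C#N)nc21` differs from compound 2 by chloro in place of hydrogen on an aromatic carbon. Among the compounds with values here, no measured step touches that ring, so none bears on this change, and no shift beyond the scatter is expected in this assay. Compound 3 is therefore estimated at 20000 nM, range 8000 nM to 50000 nM. That expectation amounts to a step of a 1.3-fold lower number from compound 2 to compound 3 (0.11 log units; within the scatter).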

Compound 3, half-maximal inhibitory concentration: 16500 nM
For compound 3 the middle estimate is 1.2-fold (0.08 log units) above the measured one; the measured number falls inside the stated range.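

In this assay, chloro in place of hydrogen on the six-membered aromatic ring of carbon only gives a 1.6-fold lower number from compound 2 to compound 3 (0.20 log units; within the scatter). Within the data shown here, this is the only reading on that ring, and it shows that this position takes chloro with no shift beyond the scatter, while compound 3 still gives a number rather than a limit. No measurement shown offers a reason for the size of this step.

Open, as far as these compounds go, is whether methoxy, a carboxylic acid or an amine at this place would move the number beyond the scatter. Also open, from the compounds shown here alone, is how chloro reads with the pyrrolidin-1-yl chain of compound 1.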